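The source may report more compounds than this note shows. Statements on the series, on what has been measured and on what is new or still open speak of the compounds shown alone.

In a functional assay on HeLa cells (Homo sapiens) for cytotoxicity, read by WST assay, with a stated time of 48 h (a higher number here means a weaker inhibitor, a lower number a stronger inhibitor), compound 1 `COc1cc(C(c2ccc(O)c(OC)c2)[C@@H](CO)C(C)C)ccc1O` reaches only a limit, > 100000 nM. Compound 2 `CC[C@H](C(C)C)C(c1ccc(O)c(OC)c1)c1ccc(O)c(OC)c1` gives 9700 nM and compound 3 `COc1cc(C(c2ccc(O)c(OC)c2)[C@H](CC(C)C)C(C)C)ccc1O` gives 8200 nM. Among the measured compounds shown here, compound 3 therefore stands level with compound 2, the only other compound with a number, as the step between them shows: a 1.2-fold lower number from compound 2 to compound 3 (0.07 log units; within the scatter).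

Compound 4 `COc1cc(C(c2ccc(O)c(OC)c2)[C@H](C)[C@@H](C)CF)ccc1O` differs from compound 3 at one place: 2-(fluoromethyl)-1-methylpropyl in place of 1-isopropyl-3-methylbutyl on a saturated chain carbon bound to two aromatic carbons. The 2-(fluoromethyl)-1-methylpropyl group has no ring and no net charge. The large steps, an at least 10-fold lower number from compound 1 to compound 2 (1.01 log units; beyond the scatter) and an at least 12-fold lower number from compound 1 to compound 3 (1.08 log units; beyond the scatter), both remove the 1-(hydroxymethyl)-2-methylpropyl group of compound 1, which compound 4 also lacks. The closer guide is the exchange among chains without that group, where a 1.2-fold lower number from compound 2 to compound 3 (0.07 log units; within the scatter) stays within the scatter. For the measured compounds named here, no measured compound carries a fluoromethyl group, so this part of the change is untested, and the range is kept wide. No step beyond the scatter is therefore expected in this assay. The expected outcome is a 1.3-fold higher number from compound 3 to compound 4 (0.13 log units; within the scatter). For compound 4 the estimate is 11000 nM, with an expected range from 4500 nM to 35000 nM.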

Compound 4, half-maximal inhibitory concentration: 34000 nM
The estimate for compound 4 lay 3.1-fold (0.49 log units) below the measured number; measured number inside the range.
By their numbers in this assay, from the lowest: compounds 3 and 2 (each within the scatter of the next); then compound 4. At a limit, above all of these: compound 1.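

In this assay, the saturated chain carbon bound to two aromatic carbons turns out to respond to exchanges among chains without a hydroxymethyl group, which the earlier step of a 1.2-fold lower number from compound 2 to compound 3 (0.07 log units; within the scatter) had not shown: the 2-(fluoromethyl)-1-methylpropyl group gives a 4.1-fold higher number from compound 3 to compound 4 (0.62 log units; beyond the scatter) and a 3.5-fold higher number from compound 2 to compound 4 (0.54 log units; beyond the scatter). Compound 4 still differs from the hydroxymethyl-bearing chain, with an at least 2.9-fold lower number from compound 1 to compound 4 (0.46 log units; beyond the scatter), so it falls apart from both the two chains without fluorine and compound 1. That last step rests on a limit for compound 1, not on a number: the limit of > 100000 nM in this assay, at which 1 of the 4 values shown sits.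

The fluorine and the change in chain arrive together in compound 4, so the compounds shown do not separate their contributions. Going by these compounds, how a chain ending in an amine or a carboxylic acid would read at this place also stays open.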